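The source may report more compounds than this note shows. Statements on the series, on what has been measured and on what is new or still open speak of the compounds shown alone.

Of the compounds shown here, two of one shared core have been measured so far. Compound 1, `C/C(=N\NC(=O)/C(C#N)=C/c1ccccc1)c1c(O)c2ccc(O)cc2oc1=O`, gives 19200 nM in a functional assay on MCF7 cells (Homo sapiens) for cytotoxicity, read by MTT assay, with a stated time of 24 h; a lower number here means a stronger inhibitor, a higher number a weaker inhibitor. Within the data shown here, compound 2, `C/C(=N\NC(=O)/C(C#N)=C/c1ccc(O)cc1)c1c(O)c2ccc(O)cc2oc1=O`, gives 7320 nM in the same test, which is the lowest of the two numbers; its only neighbour is compound 1, and the step is a 2.6-fold lower number from compound 1 to compound 2 (0.42 log units; beyond the scatter), so adding the hydroxy group to the ring made the compound a modestly stronger inhibitor.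

Compound 3, `C/C(=N\NC(=O)/C(C#N)=C/c1ccccc1[N+](=O)[O-])c1c(O)c2ccc(O)cc2oc1=O`, has not been measured yet. It differs from compound 2 in one place: 2-nitrophenyl in place of 4-hydroxyphenyl on a double-bonded chain carbon bound to a double-bonded chain carbon. The hydroxy group that helped in the step from compound 1 to compound 2 is therefore gone again, and a nitro group now sits on the ring instead. Among the measured compounds shown here, only that one step bears on the question, and nothing measured here shows what a nitrophenyl group does on this core. The expectation is that losing the hydroxy group returns the number toward that of compound 1, so a step of about a 2.0-fold higher number from compound 2 to compound 3 (0.31 log units; beyond the scatter) toward a weaker inhibitor is expected. For compound 3 the estimate is 15000 nM, within a range from 6000 nM to 40000 nM.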

Compound 3, half-maximal inhibitory concentration: 9180 nM
The estimate for compound 3 lay 1.6-fold (0.21 log units) above the measured number, and the stated range covers the measured number.
By their numbers in this assay, from the lowest: compounds 2 and 3 (each within the scatter of the next); then compound 1.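

Compound 3 shows that the hydroxy group is not the only addition to the plain phenyl ring of compound 1 that goes with a stronger inhibitor: in this assay, a nitro group in place of hydrogen gives a 2.1-fold lower number from compound 1 to compound 3 (0.32 log units; beyond the scatter). Exchanging 4-hydroxyphenyl for 2-nitrophenyl gives a 1.3-fold higher number from compound 2 to compound 3 (0.10 log units; within the scatter), so this test does not separate the two substituted rings, and among these compounds a hydrogen-bond donor on the ring is not required for a number at this level. No measurement here accounts for these numbers.

The names 4-hydroxyphenyl and 2-nitrophenyl show that both the group and its place on the ring differ, so these compounds cannot separate the effect of the group from the effect of where it sits. From the compounds shown here alone, it also remains open whether other groups on this ring, such as an amine, a carboxylic acid or a chlorine atom, would match these two or give a number clearly different from both.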